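Aryl amide swaps on a shared core against HeLa proliferation

The source may hold more compounds than are shown below. What is called first, only, known or untested is meant among the compounds shown, and "the series" means these compounds.

Compound 1 `NC(=O)c1c(NC(=O)c2ccccc2Br)sc2c1CCN(C(=S)Nc1ccccc1Cl)C2` gives 46900 nM in a functional assay on HeLa cells (Homo sapiens) for antiproliferative activity, with a stated time of 24 h; a higher number here means a weaker inhibitor, a lower number a stronger inhibitor; compound 2 `CSc1ccccc1C(=O)Nc1sc2c(c1C(N)=O)CCN(C(=S)Nc1ccccc1Cl)C2` gives 34700 nM; compound 3 `Cc1ccc(C(=O)Nc2sc3c(c2C(N)=O)CCN(C(=S)Nc2ccccc2Cl)C3)cc1` gives 26300 nM.

Compound 3 holds the lowest of the three numbers in this assay, but its separation from its neighbours is modest: a 1.3-fold lower number from compound 2 to compound 3 (0.12 log units; within the scatter) and a 1.8-fold lower number from compound 1 to compound 3 (0.25 log units; within the scatter). Compound 4 `NC(=O)c1c(NC(=O)c2ccncn2)sc2c1CCN(C(=S)Nc1ccccc1Cl)C2` differs from compound 3 in one place, (pyrimidin-4-yl in place of 4-methylphenyl on a carbonyl carbon). For the measured compounds named here, none of the measured steps tests a heteroaromatic ring in this position; the nearest comparisons, a 1.4-fold lower number from compound 1 to compound 2 (0.13 log units; within the scatter) and a 1.3-fold lower number from compound 2 to compound 3 (0.12 log units; within the scatter), show that swaps of the aryl amide have all stayed inside the scatter. On that basis compound 4 is expected to show a 1.3-fold higher number from compound 3 to compound 4 (0.12 log units; within the scatter), a step without direction beyond the scatter, and its estimated value is 35000 nM in this assay, ranging from 14000 nM to 85000 nM.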

Compound 4, half-maximal inhibitory concentration: > 50000 nM
Compound 4 ended at the assay's limit; the forecaster's own chance of this, stated with the estimate: 15%; middle value at least 1.4-fold (0.15 log units) away from the limit.
By their numbers in this assay, from the lowest: compounds 3, 2 and 1 (each within the scatter of the next). At a limit, above all of these: compound 4.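

In this assay compound 4 reads > 50000 nM, a limit of the assay and not a number, and it alone ends there: the limit of > 50000 nM in this assay, at which 1 of the 4 values shown sits. Pyrimidin-4-yl is the first ring with hetero atoms shown on this carbonyl carbon, and it is the only swap here to reach that limit. Yet each floor lies within the scatter, so no loss is established: an at least 1.9-fold higher number from compound 3 to compound 4 (0.27 log units; that floor lies within the scatter), an at least 1.4-fold higher number from compound 2 to compound 4 (0.15 log units; that floor lies within the scatter) and an at least 1.0-fold higher number from compound 1 to compound 4 (0.02 log units; that floor lies within the scatter).

Going by these compounds, how far the true value of compound 4 lies from the others stays open. So does whether a pyridinyl ring, with a single ring nitrogen, or an amine on the phenyl ring would reach the same limit.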